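A Benzyl Swap in a Pancreatic Cell Growth Series

The compounds below may be only part of what the source reports. "The series", "measured", "known", "first", "only" and "open" are said of these compounds alone.

Compound 1 `CCCCc1ccc(S(=O)(=O)NCCCCCCNCc2ccc(Br)cc2)cc1`: in a functional assay on MIA PaCa-2 cells (Homo sapiens) for inhibition, read by MTT assay, with a stated time of 72 h (a lower number here means a stronger inhibitor of growth, a higher number a weaker inhibitor of growth), compound 1 gives 5700 nM
Compound 2 `O=S(=O)(NCCCCNCc1ccc(Br)cc1)c1cc(C(F)(F)F)cc(C(F)(F)F)c1`: in this assay compound 2 gives 2100 nM
Compound 3 `O=S(=O)(NCCCNCc1ccc(Cl)cc1)c1cc(C(F)(F)F)cc(C(F)(F)F)c1`: in this assay compound 3 gives 2800 nM

Compound 3 holds the second highest of the three numbers. Its nearest neighbour is compound 2, where the step of a 1.3-fold higher number from compound 2 to compound 3 (0.12 log units; within the scatter) stays within the scatter; the furthest is compound 1, whose number is higher than that of compound 3 by an amount beyond the scatter.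

Compound 4 `COc1cccc(CNCCCNS(=O)(=O)c2cc(C(F)(F)F)cc(C(F)(F)F)c2)c1` differs from compound 3 in one place: 3-methoxyphenyl in place of 4-chlorophenyl on a saturated chain carbon bound to an amine nitrogen. Going by the values given here, the only measured step, from compound 2 to compound 3, touches the chain and the halogen and not this exchange, so no measured step bears on it. With nothing to push in either direction, no step beyond the scatter is expected in this assay, and the estimated step of a 1.3-fold higher number from compound 3 to compound 4 (0.10 log units; within the scatter) is taken as flat. Compound 4 is therefore expected to give about 3500 nM, within a range from 1500 nM to 8000 nM.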

Compound 4, concentration for 50% growth inhibition: 3400 nM
Compound 4: the middle estimate sits 1.0-fold (0.01 log units) above what was measured; the range from low to high includes it.
By their numbers in this assay, from the lowest: compounds 2, 3, 4 and 1 (each within the scatter of the next, the first and the last beyond it).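

In this assay, the exchange of 4-chlorophenyl for 3-methoxyphenyl on a saturated chain carbon bound to an amine nitrogen gives a 1.2-fold higher number from compound 3 to compound 4 (0.08 log units; within the scatter), so at this position a chlorine can give way to a methoxy group, which adds one hydrogen-bond acceptor, without a step beyond the scatter. The wider change reads the same way, with a 1.6-fold higher number from compound 2 to compound 4 (0.21 log units; within the scatter), so this pair also stays within the scatter when the amine side differs by both the aryl group and the chain. Nothing available explains why these numbers stay so close.

Because chlorine and methoxy differ in both identity and ring position, the compounds shown do not separate those two changes. Going by these compounds, how 4-methoxyphenyl, 3-chlorophenyl, unsubstituted phenyl or a phenyl ring bearing a carboxylic acid would read at this position remains open.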